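Estimating compound 4 from one analogous step

The source may report more compounds than this note shows. Statements on the series, on what has been measured and on what is new or still open speak of the compounds shown alone.

Compound 1 `C=C1[C@@H](O)C[C@H]2C(C)(C)CCC[C@]2(C)[C@H]1/C=C/c1ccoc1` gives 4.22 ug/mL in a functional assay on HUVEC cells (Homo sapiens) for inhibition, read by colorimetric assay and MTT assay; a lower number here means a stronger inhibitor, a higher number a weaker inhibitor. Among the three measured compounds its number is the second highest of three. Its nearest neighbour is compound 2 `C=C1[C@@H](O[Si](C)(C)C(C)(C)C)C[C@H]2C(C)(C)CCC[C@]2(C)[C@H]1C[C@@H](O)c1ccoc1`, which in this assay gives 3.76 ug/mL, a gap that lies within the usual scatter, so the two are not distinguished. Furthest from it is compound 3 `C=C1[C@@H](O)C[C@H]2C(C)(C)CCC[C@]2(C)[C@H]1C[C@@H](O)c1ccoc1`, which in this assay gives 15 ug/mL, a gap beyond the scatter.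

Compound 4 `C=C1[C@@H](O[Si](C)(C)C(C)(C)C)C[C@H]2C(C)(C)CCC[C@]2(C)[C@H]1/C=C/c1ccoc1` differs from compound 1 in one place: a group of 7 heavy atoms (6 carbon, 1 silicon; no ring) in place of a hydrogen atom, on an oxygen on a saturated carbon. Going by the values given here, the only measured step that bears on this change is a 4.0-fold higher number from compound 2 to compound 3 (0.60 log units; beyond the scatter), in which the same group of 7 heavy atoms left the same oxygen on a saturated carbon. The change from compound 1 to compound 4 runs in the opposite direction, so a lower number of about that size is expected. Among the compounds with values here, the side chain of compound 1 and compound 4 is not the same as that of compound 2 and compound 3, and only this one step is available, so the expectation carries a wide margin.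

On that basis the step of a 3.2-fold lower number from compound 1 to compound 4 (0.51 log units; beyond the scatter) is expected. Compound 4 is estimated at 1.3 ug/mL, with a range from 0.5 ug/mL to 4 ug/mL.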

Compound 4, half-maximal inhibitory concentration: > 50 ug/mL
Compound 4: no number, only a limit; the forecaster's own chance of this, stated with the estimate: 3%; at least 38-fold (1.58 log units) between middle value and limit.
By their numbers in this assay, from the lowest: compounds 2 and 1 (each within the scatter of the next); then compound 3. At a limit, above all of these: compound 4.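

In this assay compound 4 gives > 50 ug/mL, which is a limit of the assay and not a number, and it is the only one of the compounds shown to sit there: the limit of > 50 ug/mL in this assay, at which 1 of the 4 values shown sits. With the hydroxyethyl side chain replaced by 2-(furan-3-yl)ethenyl, the group of 7 heavy atoms on this oxygen no longer goes with the lower number seen in compound 2, since the side-chain change alone gives an at least 13-fold higher number from compound 2 to compound 4 (1.12 log units; beyond the scatter). Adding that group to the oxygen of compound 1 gives an at least 11-fold higher number from compound 1 to compound 4 (1.07 log units; beyond the scatter), so the outcome of this change at this oxygen depends on the side chain carried by the saturated ring carbon, and the two available cases point in opposite directions: the same change on two cores in this assay, a 4.0-fold higher number (0.60 log units; beyond the scatter) from compound 2 to compound 3 and an at least 11-fold lower number (1.07 log units; beyond the scatter) from compound 4 to compound 1, at least 47-fold (1.67 log units) apart, beyond the scatter of two such steps.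

As far as these compounds go, whether a methyl or an acetyl group on the same oxygen would follow compound 1 or compound 4 stays open, as does the outcome of such a change with any other side chain on that ring carbon. From the compounds shown here alone, how far the true value of compound 4 lies past its limit also remains unknown, so the size of both new steps is only a lower bound.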